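Acetyl Capping of a Hydroxy Group: an Expected Shift

The compounds below may be only part of what the source reports. "The series", "measured", "known", "first", "only" and "open" are said of these compounds alone.

Of the compounds shown here, three sharing one core have been measured in a functional assay on FM3A cells (Homo sapiens) for inhibition, with FM3A (Mus musculus) as the target; on this read-out higher numbers stand for weaker inhibition and lower numbers for stronger inhibition. Compound 1 `CC(=O)OC(C)n1cnc2c(Cl)nc(I)nc21` gives 47000 nM. Compound 2 `CC(O)n1cnc2c(N)nc(I)nc21` gives 452000 nM, the higher of the two plain numbers, with compound 1 as the nearest neighbour below it. Compound 3 `Nc1nc(I)nc2c1ncn2OCCO` returns only > 500000 nM, which is a limit of this assay and not a number. One of the three values thus sits at the limit of > 500000 nM in this assay, at which 1 of the 3 values shown sits. Going by the values given here, the only single-change step measured, an at least 1.1-fold higher number from compound 2 to compound 3 (0.04 log units; that floor lies within the scatter), places 2-hydroxyethoxy in place of 1-hydroxyethyl on an aromatic nitrogen and ends at that limit, so it sets no size.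

Compound 4 `CC(=O)OC(C)n1cnc2c(N)nc(I)nc21` is not yet measured. It differs from compound 2 by acetyl in place of hydrogen on an oxygen on a saturated carbon. Among the compounds with values here, no measured step covers acetylation of a hydroxy group; compound 1 carries the acetoxy group but differs from compound 4 in a second place as well, so its value cannot be assigned to that change alone. Compound 4 is therefore expected near 150000 nM, within 40000 nM to 500000 nM, an estimated step of a 3.0-fold lower number from compound 2 to compound 4 (0.48 log units; beyond the scatter).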

Compound 4, half-maximal inhibitory concentration: 462000 nM
Estimate against measurement, compound 4: 3.1-fold (0.49 log units) below; low and high end bracket the measured number.
By their numbers in this assay, from the lowest: compound 1; then compounds 2 and 4 (each within the scatter of the next). At a limit, above all of these: compound 3.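

In this assay, hydroxy and acetoxy on this saturated carbon read alike, with a 1.0-fold higher number from compound 2 to compound 4 (0.01 log units; within the scatter) for acetyl in place of hydrogen on the oxygen. Going by these compounds alone, the gap to compound 1 can now be set against a single difference, amino in place of chloro on an aromatic carbon, with a 9.8-fold higher number from compound 1 to compound 4 (0.99 log units; beyond the scatter) for that swap, a step the earlier compounds could not isolate. Nothing shown here speaks to the reason for either step.

The compounds shown leave open whether a propionyl ester or a methyl ether on this oxygen would read alike as well, and whether a methylamino group on the aromatic carbon would stand with amino or with chloro. On these data alone, whether hydroxy and acetoxy also read alike with chloro on that aromatic carbon stays open too.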